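Dropping a Methyl Group: Compound 2 to Compound 3

A few compounds are considered here, and "the series" means these few. Any claim that something is new, unique, unknown or untested is made for them only; others in the source may bear on it.

Compound 1 `N/C(=N\NC(=S)N1CCCCCC1)c1ccccn1` gives 77.5% in a functional assay on A-431 cells (Homo sapiens) for cytotoxicity, read by MTT assay, with a stated time of 72 h, tested at 100 uM; a higher number here means more inhibition of growth at the concentration tested, a lower number less inhibition of growth.
Compound 2 `Cc1cccc(/C(N)=N/NC(=S)N2CCSCC2)n1` gives 80.7% in this assay.

Compound 2 has the highest of the two numbers, yet compound 1 sits within the scatter of it, so no order can be read between the two. Compound 3 `N/C(=N\NC(=S)N1CCSCC1)c1ccccn1` differs from compound 2 by hydrogen in place of methyl on an aromatic carbon. For the measured compounds named here, no measured pair isolates this change, and compounds 1 and 2, which differ in two places, give numbers within the scatter of each other. The step of a number 2.7 percentage points lower from compound 2 to compound 3 (within the scatter) is therefore expected to be small, most likely within the scatter in either direction. Compound 3 is estimated at 78%, between 64% and 90%.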

Compound 3, percent growth inhibition at one concentration: 80.8%
Beside the measured number, compound 3's estimate is 2.8 percentage points below it, within the range that was stated.
By their numbers in this assay, from the lowest: compounds 1, 2 and 3 (each within the scatter of the next).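

In this assay, hydrogen in place of methyl on the aromatic carbon next to the ring nitrogen gives a number 0.1 percentage points higher from compound 2 to compound 3 (within the scatter). For the compounds shown here, this is the first pair to isolate the change, and at the tested concentration, removing the methyl from this position leaves no readable difference in growth inhibition. Nothing given here bears on why the two compounds read alike.

On these data alone, whether an amine, a carboxylic acid or a longer chain at this place would also read alike stays open. The single concentration also leaves open whether compound 2 and compound 3 would separate at lower concentrations.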